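This account rests on a few compounds, and the source may have more. Where it says the series, first, only, none or still open, it means among the compounds named here.

Measured compounds in an assay on isolated protein (Cavia porcellus) with cysteinyl leukotriene receptor (Homo sapiens) as the target; a higher number here means a more potent compound, by a factor of ten per unit of this negative logarithm, a lower number a less potent compound:

compound 1 `CCCn1cc(Cc2ccc(C(=O)NS(=O)(=O)c3ccccc3)cc2OC)c2cc(NC(=O)OC3CCCC3)ccc21` gives 8.44
compound 2 `COc1cc(C(=O)NS(=O)(=O)c2ccccc2C)ccc1Cc1cn(C)c2ccc(NC(=O)CC3CCCC3)cc12` gives 9.64
compound 3 `COc1cc(C(=O)NS(=O)(=O)c2ccccc2)ccc1Cc1cn(C)c2ccc(NC(=O)CC3CCCC3)cc12` gives 9.8

Compound 2 stands second of the three numbers in this assay; compound 3 sits within the scatter of it, whereas compound 1 lies beyond the scatter, lower.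

Compound 4 `COc1cc(C(=O)NS(=O)(=O)c2ccccc2C)ccc1Cc1cn(C)c2ccc(NC(=O)NC3CCCC3)cc12` follows from compound 2 by the change (cyclopentylamino in place of cyclopentylmethyl on a carbonyl carbon). Among the compounds with values here, the only step measured in one place, a number 0.16 log units higher from compound 2 to compound 3 (within the scatter), concerns hydrogen in place of methyl on an aromatic carbon and does not touch the carbonyl carbon in question, so it gives no direct guide. Compound 1 differs from compound 2 in several places at once, so its value shows only that the series spans a gap beyond the scatter. Within the data shown here, with no step bearing on this change, compound 4 is expected to stay close to compound 2, with a step of a number 0.24 log units lower from compound 2 to compound 4 (within the scatter) not beyond the scatter. The estimate for compound 4 is 9.4, range 8.7 to 10.1.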

Compound 4, negative logarithm of the antagonist equilibrium constant: 9.31
Estimate against measurement, compound 4: 0.09 log units above; low and high end bracket the measured number.
By their numbers in this assay, from the lowest: compound 1; then compound 4; then compounds 2 and 3 (each within the scatter of the next).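

Within the data shown here, at the carbonyl carbon, this assay now gives a first measured step for cyclopentylamino in place of cyclopentylmethyl (a number 0.33 log units lower from compound 2 to compound 4 (beyond the scatter)), so this position is not indifferent to the exchange, though the step is modest. The exchange keeps the five-membered ring and the count of heavy atoms, while a nitrogen replaces a carbon and one hydrogen-bond donor enters. No measurement at hand explains the step.

Open, from the compounds shown here alone, is whether a cyclohexylamino or an open-chain butylamino group on the same carbonyl carbon would hold the value. Also open, going by these compounds, is whether the step recurs with hydrogen in place of methyl on the aromatic carbon, as in compound 3.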